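The compounds below may be only part of what the source reports. "The series", "measured", "known", "first", "only" and "open" are said of these compounds alone.

Two members of the series are in hand. Compound 1 `COc1ccc(-c2nc(C)c(C(=O)CSc3nc(N)c(C#N)c(-c4ccc(OC)cc4)n3)s2)cc1` and compound 2 `Cc1nc(-c2ccc(Cl)cc2)sc1C(=O)CSc1nc(N)c(C#N)c(-c2ccc(Cl)cc2)n1` share one core. In a functional assay on U-87MG ATCC cells for antiproliferative activity against U-87 MG (Homo sapiens), read by MTT assay, with a stated time of 48 h, tested at 50 uM (on this read-out lower numbers stand for a stronger effect and higher numbers for a weaker effect at the one concentration tested), compound 1 gives 13% and compound 2 gives 15.5%; the two numbers lie within the usual scatter of each other, so compound 2 is not set apart from compound 1 on this read-out.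

Compound 3 `COc1ccc(-c2nc(SCC(=O)c3sc(-c4ccc(Cl)cc4)nc3C)nc(N)c2C#N)cc1` is next. Against compound 2 the change is methoxy in place of chloro on an aromatic carbon. Among the measured compounds shown here, no measured step of this kind exists. Given that compound 1 and compound 2 already lie so close, the step from compound 2 to compound 3 is expected to stay within the scatter, a number 1.5 percentage points lower from compound 2 to compound 3 (within the scatter). Compound 3 is estimated at 14%, with a range of 5% to 25%.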

Compound 3, a percentage reported as activity, at one concentration (the size of the read-out at that concentration, not a potency): 17.8%
For compound 3 the middle estimate is 3.8 percentage points below the measured one; the range from low to high includes it.
By their numbers in this assay, from the lowest: compounds 1, 2 and 3 (each within the scatter of the next).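

On this assay, methoxy in place of chloro on an aromatic carbon stays within the scatter (a number 2.3 percentage points higher from compound 2 to compound 3 (within the scatter)), and so does chloro in place of methoxy on the other six-membered aromatic ring (a number 4.8 percentage points higher from compound 1 to compound 3 (within the scatter)). The read-out therefore does not separate these two groups at either place, which compound 1 and compound 2, differing in two places, could not show. No measurement at hand bears on a cause for these steps. Going by these compounds, whether an amine or a carboxylic acid at this position would give a step beyond the scatter stays open.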